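Compound 3 to compound 4: changing the benzylic amine

The source may report more compounds than this note shows. Statements on the series, on what has been measured and on what is new or still open speak of the compounds shown alone.

In a functional assay on NCI-H460 cells (Homo sapiens) for inhibition, read by sulforhodamine B assay, with a stated time of 72 h (on this read-out lower numbers stand for stronger inhibition and higher numbers for weaker inhibition), compound 3 `CCNC(=O)c1nnn(-c2cc(C(C)C)c(O)cc2O)c1-c1ccc(CN(CC)CC)cc1` gives 11 nM and compound 2 `CCNC(=O)c1nnn(-c2cc(C(C)C)c(O)cc2O)c1-c1ccc(CN2CCCC(O)C2)cc1` gives 62 nM, so compound 3 holds the lower of the two numbers. Compound 1 `CC(C)c1cc(-n2cc(-c3ccc(CN4CCN(Cc5ccccc5)CC4)cc3)nn2)c(O)cc1O` gives > 1000 nM in this assay, which is a limit of the assay and not a number.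

The next change leads to compound 4 `CCNC(=O)c1nnn(-c2cc(C(C)C)c(O)cc2O)c1-c1ccc(CN2CCC(N(C)C)CC2)cc1`, with 4-(dimethylamino)piperidin-1-yl in place of diethylamino on a saturated chain carbon bound to an aromatic carbon.

Among the measured compounds shown here, only one measured step bears on this place: a 5.6-fold lower number from compound 2 to compound 3 (0.75 log units; beyond the scatter). In that pair, compound 2 carries a six-membered non-aromatic ring on the same carbon and has the higher number, while compound 3 carries diethylamino. Compound 4 also brings in such a ring, but with a different substituent, so this single pair is only a loose guide. A modest move toward weaker inhibition is therefore expected, of similar or smaller size than the measured step. The expected change is a 2.7-fold higher number from compound 3 to compound 4 (0.44 log units; beyond the scatter).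

For compound 4 the estimated value is 30 nM, with an expected range of 8 nM to 110 nM.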

Compound 4, half-maximal inhibitory concentration: 120 nM
The estimate for compound 4 lay 4.0-fold (0.60 log units) below the measured number, outside the stated range (above it).
By their numbers in this assay, from the lowest: compound 3; then compounds 2 and 4 (each within the scatter of the next). At a limit, above all of these: compound 1.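

In this assay, the new step is an 11-fold higher number from compound 3 to compound 4 (1.04 log units; beyond the scatter), so this position responds strongly to 4-(dimethylamino)piperidin-1-yl in place of diethylamino. The two ring amines cannot be told apart despite their different substituents, with a 1.9-fold higher number from compound 2 to compound 4 (0.29 log units; within the scatter), so the earlier gap between 3-hydroxypiperidin-1-yl and diethylamino, a 5.6-fold lower number from compound 2 to compound 3 (0.75 log units; beyond the scatter), now has a second ring amine on the same side of it and no listed compound with a ring on this carbon goes against that pattern. The only measured limit shown belongs to a compound that differs in more than one place, so nothing given here bears on the cause of the step.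

With one open-chain amine and two piperidines at this position, the compounds shown do not separate the effect of the ring from that of the larger group, as 4-(dimethylamino)piperidin-1-yl also carries more heavy atoms than diethylamino. A pyrrolidin-1-yl ring, a morpholin-4-yl ring or an open-chain amine such as dimethylamino or dipropylamino on the same carbon would help separate the two.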